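Swapping a Dimethoxyphenyl for Thiophene on a Weak Scaffold

The source may hold more compounds than are shown below. What is called first, only, known or untested is meant among the compounds shown, and "the series" means these compounds.

Compound 1 `COc1ccc(-c2nc3cccc(-c4cc(OC)c(OC)c(OC)c4)c3o2)cc1OC` was tested in a functional assay on MCF7 cells (Homo sapiens) for antiproliferative activity, read by MTT assay, with a stated time of 48 h; on this read-out higher numbers stand for weaker inhibition and lower numbers for stronger inhibition. In this assay compound 1 gives > 25000 nM, which is a limit of the assay and not a measured number. Compound 2 `COc1cc(-c2cccc3nc(-c4ccc(N)cc4)oc23)cc(OC)c1OC` gives > 25000 nM in this assay, again a limit. Within the data shown here, the one measured step, a step that the two limits leave unreadable from compound 1 to compound 2, therefore cannot be sized, because the limit of > 25000 nM in this assay, at which 2 of the 2 values shown sit, covers both values.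

Compound 3 `COc1cc(-c2cccc3nc(-c4cccs4)oc23)cc(OC)c1OC` has not yet been measured. It differs from compound 1 as follows: thiophen-2-yl in place of 3,4-dimethoxyphenyl on an aromatic carbon. Among the measured compounds shown here, since the single measured step has no readable size, nothing in these data points to a change in either direction beyond the usual scatter, and a value at the same limit remains the most likely outcome. Compound 3 is therefore expected to give about 30000 nM, within a range of 8000 nM to 100000 nM. The expected step amounts to a step that the limit leaves unreadable from compound 1 to compound 3.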

Compound 3, half-maximal inhibitory concentration: > 25000 nM
Compound 3 gave a limit, no number; the forecaster's own chance of this, stated with the estimate: 70%; the middle value does not contradict the limit.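

No step among compound 1, compound 2 and compound 3 can be read, because each result is a limit and not a number: the limit of > 25000 nM in this assay, at which 3 of the 3 values shown sit.

The compounds shown leave open how far these three differ, and whether any group at this place on the shared core gives a measurable value.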